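This account rests on a few compounds, and the source may have more. Where it says the series, first, only, none or still open, it means among the compounds named here.

Measured in a functional assay on HeLa cells (Homo sapiens) for antiproliferative activity; a higher number here means a weaker inhibitor, a lower number a stronger inhibitor:
- compound 1 `COc1ccc2nc(Cl)c(C3CC(c4ccc(C)cc4)=NN3c3nc(-c4ccc(Cl)cc4)cs3)cc2c1`: 38 nM
- compound 2 `COc1ccc2nc(Cl)c(C3CC(c4ccc(C)cc4)=NN3c3nc(C)c(/N=N/c4ccccc4)s3)cc2c1`: 38 nM
- compound 3 `COc1ccc2nc(O)c(/C=C/C(=O)c3ccc(C)cc3)cc2c1`: 38 nM

In this assay compound 1 stands at 38 nM, level with both other compounds within the usual scatter. Compound 4 `COc1ccc2nc(Cl)c(C3CC(c4ccc(C)cc4)=NN3c3nc(-c4ccc(C)cc4)cs3)cc2c1` has not yet been measured. It departs from compound 1 at one place, methyl in place of chloro on an aromatic carbon, turning 4-chlorophenyl into 4-methylphenyl. Going by the values given here, no two measured compounds differ in only one place, so this swap has no direct precedent here. The expectation therefore rests on compound 1 at 38 nM and on the structurally different compound 2 at 38 nM. In this assay no change beyond the scatter is expected, and no direction is favoured, so the estimated 1.1-fold higher number from compound 1 to compound 4 (0.02 log units; within the scatter) is small. For compound 4 the estimated value is 40 nM, with an expected range of 14 nM to 115 nM.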

Compound 4, half-maximal inhibitory concentration: 38 nM
Compound 4: the middle estimate sits 1.1-fold (0.02 log units) above what was measured, and the stated range covers the measured number.
By their numbers in this assay, from the lowest: compounds 1, 2, 3 and 4 (each within the scatter of the next).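

In this assay, going by these compounds alone, the swap of chloro for methyl gives no change at the digits printed from compound 1 to compound 4 (within the scatter) and provides the first comparison here between two compounds differing in only one place. At this spot on the outer phenyl ring, para to a large group, these two small groups cannot be told apart by this read-out. Nothing measured here bears on the reason for this result. From the compounds shown here alone, whether an amine, a carboxylic acid or a longer chain such as butyl would be matched as well in place of the chloro remains open.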